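A Methyl Ester Grows by One Carbon

The compounds below may be only part of what the source reports. "The series", "measured", "known", "first", "only" and "open" are said of these compounds alone.

Of the compounds shown here, three with one shared core have been tested in a functional assay on MIA PaCa-2 cells (Homo sapiens) for cytotoxicity, read by MTT assay, with a stated time of 72 h; a lower number here means a stronger inhibitor, a higher number a weaker inhibitor. Compound 1 `COC(=O)c1ccc(NC2=CC(=O)c3ncncc3C2=O)cc1` gives 2200 nM. Compound 2 `CC(=O)c1cccc(NC2=CC(=O)c3ncncc3C2=O)c1` gives 2300 nM, and compound 3 `COc1cccc(NC2=CC(=O)c3ncncc3C2=O)c1` gives 1800 nM. All three numbers sit within the scatter of one another, so compound 1 stands among them with nothing to separate it from compound 2 or compound 3. Among the measured compounds shown here, the only single-point step among the measured compounds, a 1.3-fold lower number from compound 2 to compound 3 (0.11 log units; within the scatter), concerns a group on the aromatic ring and barely moved the number.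

Compound 4 `CCOC(=O)c1ccc(NC2=CC(=O)c3ncncc3C2=O)cc1` has not yet been measured. It differs from compound 1 by one change: methyl in place of hydrogen on a saturated chain carbon bound to an oxygen next to a carbonyl group. For the measured compounds named here, no measured step tracks this exact change, and the one step that exists was within the scatter, so nothing in the data points to a move beyond the scatter in this assay in either direction.

For compound 4 the expected value in this assay is 2200 nM, with a range from 1100 nM to 4400 nM. That estimate means the step of no change at the digits printed from compound 1 to compound 4 (within the scatter) is expected to stay within the scatter.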

Compound 4, half-maximal inhibitory concentration: 5500 nM
Compound 4: middle estimate off by 2.5-fold (0.40 log units), on the low side; measured number above the stated range.
By their numbers in this assay, from the lowest: compounds 3, 1 and 2 (each within the scatter of the next); then compound 4.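

In this assay, the ester of compound 1 proves sensitive to a small change: replacing methoxycarbonyl with ethoxycarbonyl gives a 2.5-fold higher number from compound 1 to compound 4 (0.40 log units; beyond the scatter) in a single step. This modest step is the only one shown that lies beyond the scatter, whereas a 1.3-fold lower number from compound 2 to compound 3 (0.11 log units; within the scatter) at a different place on the aromatic ring stays within it. Nothing measured here bears on the reason for the shift, so the step can be reported only by its size.

A single step cannot show whether the number would keep rising along a longer chain, such as a propyl or butyl ester, or whether a branched isopropyl ester would behave like the ethyl one. It also leaves open what a carboxylic acid or a primary amide would do in place of the ester.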